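The compounds below may be only part of what the source reports. "The series", "measured", "known", "first", "only" and "open" are said of these compounds alone.

Of the compounds shown here, three share one core and have been tested in a functional assay on NCI-H460 cells (Homo sapiens) for antiproliferative activity, with a stated time of 72 h; on this read-out higher numbers stand for weaker inhibition and lower numbers for stronger inhibition. Compound 1 `CCCCC#Cc1cc([C@@H]2O[C@H](CO)[C@@H](O)[C@H]2O)n2ncnc(N)c12` gives 1700 nM, the lowest of the three numbers. Compound 2 `Nc1ncnn2c([C@@H]3O[C@H](CO)[C@@H](O)[C@H]3O)cc(C#Cc3ccccc3)c12` gives 38500 nM, and compound 3 `Nc1ncnn2c([C@@H]3O[C@H](CO)[C@@H](O)[C@H]3O)cc(-c3ccc(F)cc3)c12` gives 55500 nM. The new compound 4 `Cc1ccccc1-c1cc([C@@H]2O[C@H](CO)[C@@H](O)[C@H]2O)n2ncnc(N)c12` differs from compound 1 in one place: 2-methylphenyl in place of hex-1-yn-1-yl on an aromatic carbon. Among the measured compounds shown here, two measured steps bear on this. Exchanging the chain for a ring-bearing group gave a 23-fold higher number from compound 1 to compound 2 (1.36 log units; beyond the scatter), and putting an aromatic ring directly on that carbon gave a 33-fold higher number from compound 1 to compound 3 (1.51 log units; beyond the scatter); between those two compounds the difference was a 1.4-fold higher number from compound 2 to compound 3 (0.16 log units; within the scatter). A comparably large loss of potency is therefore expected for compound 4, namely a 29-fold higher number from compound 1 to compound 4 (1.47 log units; beyond the scatter). In this assay compound 4 is estimated at 50000 nM, with a likely range from 15000 nM to 160000 nM.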

Compound 4, half-maximal inhibitory concentration: > 100000 nM
Compound 4 gave a limit, no number (the forecaster's own chance of this, stated with the estimate: 10%); at least 2.0-fold (0.30 log units) between middle value and limit.
By their numbers in this assay, from the lowest: compound 1; then compounds 2 and 3 (each within the scatter of the next). At a limit, above all of these: compound 4.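

Compound 4 gives a limit of the assay, not a number: the limit of > 100000 nM in this assay, at which 1 of the 4 values shown sits. All three ring-bearing groups shown on this aromatic carbon now lie far from hex-1-yn-1-yl, and 2-methylphenyl gives an at least 58-fold higher number from compound 1 to compound 4 (1.76 log units; beyond the scatter). Against 2-phenylethynyl the change gives an at least 2.5-fold higher number from compound 2 to compound 4 (0.41 log units; beyond the scatter), while against 4-fluorophenyl it gives an at least 1.8-fold higher number from compound 3 to compound 4 (0.25 log units; that floor lies within the scatter), so compounds 3 and 4 cannot be put in order.

On these data alone, it remains open whether the triple bond or the chain length goes with the low number of compound 1. A saturated hexyl group, or a shorter chain on the triple bond, would separate the two.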